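The source may hold more compounds than are shown below. What is called first, only, known or untested is meant among the compounds shown, and "the series" means these compounds.

In a functional assay on MCF7 cells (Homo sapiens) for antiproliferative activity (on this read-out lower numbers stand for stronger inhibition and higher numbers for weaker inhibition), compound 1 `CC(C)=CCc1cc(C(=O)Nc2cc3ccc(OCC4CCCN(C)C4)c(C)c3oc2=O)ccc1O` gives 2640 nM, compound 2 `CC(C)=CCc1cc(C(=O)Nc2cc3ccc(OCC4CCCNC4)c(C)c3oc2=O)ccc1O` gives 790 nM and compound 3 `CC(C)=CCc1cc(C(=O)Nc2cc3ccc(OCCCNCC(C)C)c(C)c3oc2=O)ccc1O` gives 1320 nM. Compound 3 lies within the scatter of both others. Compound 4 `CC(C)=CCc1cc(C(=O)Nc2cc3ccc(OCCCNC(C)C)c(C)c3oc2=O)ccc1O` differs from it in one group (isopropyl in place of isobutyl on an amine nitrogen), with isopropyl in place of isobutyl on an amine nitrogen. For the measured compounds named here, no measured step makes this exact change. The closest is a 3.3-fold lower number from compound 1 to compound 2 (0.52 log units; beyond the scatter), where hydrogen replaces methyl on an amine nitrogen in a ring. Replacing the ring amine with 2-(isobutylamino)ethyl gave a 2.0-fold lower number from compound 1 to compound 3 (0.30 log units; within the scatter) and a 1.7-fold higher number from compound 2 to compound 3 (0.22 log units; within the scatter). No step beyond the scatter is therefore expected in this assay. The expected step is a 1.0-fold lower number from compound 3 to compound 4 (0.01 log units; within the scatter). Compound 4 is expected at about 1300 nM, with an estimated range from 650 nM to 2600 nM.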

Compound 4, half-maximal inhibitory concentration: 740 nM
Beside the measured number, compound 4's estimate is 1.8-fold (0.24 log units) above it; measured number inside the range.
By their numbers in this assay, from the lowest: compounds 4, 2, 3 and 1 (each within the scatter of the next, the first and the last beyond it).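

In this assay, isopropyl in place of isobutyl on the amine nitrogen gives a 1.8-fold lower number from compound 3 to compound 4 (0.25 log units; within the scatter), so this small trim of the chain does not move the number beyond the scatter. The open-chain 2-(isopropylamino)ethyl group also stays level with the piperidin-3-yl ring, with a 1.1-fold lower number from compound 2 to compound 4 (0.03 log units; within the scatter) as the step. Against 1-methylpiperidin-3-yl it gives a 3.6-fold lower number from compound 1 to compound 4 (0.55 log units; beyond the scatter), a step beyond the scatter that compound 3 did not show.

Nothing here explains these numbers. Going by these compounds, whether a cyclopropyl or tert-butyl group on that amine nitrogen would fit the same range remains open.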